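The source may report more compounds than this note shows. Statements on the series, on what has been measured and on what is new or still open speak of the compounds shown alone.

Compound 1 `Cc1oc(-c2ccccc2Cl)nc1CN1CCC(C(=O)NCCCN2C[C@H](C)C[C@H](C)C2)CC1`: > 72 ug/mL
Compound 2 `Cc1ccccc1-c1nc(CN2CCC(C(=O)NCCCN3CCCCC3)CC2)c(C)o1`: > 65 ug/mL

In a physicochemical assay for solubility, in phosphate buffer, measured as kinetic solubility, at pH 7.4 (on this read-out higher numbers stand for higher solubility and lower numbers for lower solubility), compound 2 gives > 65 ug/mL, which is a limit and not a number. Compound 1 carries 3,5-dimethylpiperidin-1-yl and gives > 72 ug/mL, again a limit. Compound 3 `Cc1ccccc1-c1nc(CN2CCC(C(=O)NCCN3C[C@H](C)C[C@H](C)C3)CC2)c(C)o1` departs from compound 2 by this change: 3,5-dimethylpiperidin-1-yl in place of (piperidin-1-yl)methyl on a saturated chain carbon, two bonds along the chain from an amide-type nitrogen. Here 3,5-dimethylpiperidin-1-yl stands in place of (piperidin-1-yl)methyl on a saturated chain carbon, two bonds along the chain from an amide-type nitrogen. Among the compounds with values here, no measured step shows the size of such a change, and no shift beyond the scatter is expected in this assay. The expected step that the limit leaves unreadable from compound 2 to compound 3 is small. The estimate for compound 3 is 67 ug/mL, with an expected range of 40 ug/mL to 75 ug/mL.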

Compound 3, solubility: > 67 ug/mL
Compound 3 ended at the assay's limit; the forecaster's own chance of this, stated with the estimate: 80%; the middle value sits exactly at the limit.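

In this assay compound 2 and compound 3 both give limits and not numbers, so the step between them cannot be read. From the compounds shown here alone, whether 3,5-dimethylpiperidin-1-yl in place of (piperidin-1-yl)methyl changes this read-out at all stays open.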